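The source may report more compounds than this note shows. Statements on the series, on what has been measured and on what is new or still open speak of the compounds shown alone.

Of the compounds shown here, three sharing a core have so far been tested in a functional assay on SGC-7901 cells (Homo sapiens) for antiproliferative activity, read by MTT assay, with a stated time of 24 h (a higher number here means a weaker inhibitor, a lower number a stronger inhibitor), and none gave a number. Compound 1 `Cc1cccc(NNC(=O)c2ccc(NS(=O)(=O)c3cnc(O)nc3O)cc2)c1` gives > 20000 nM as a limit of the assay. Compound 2 `O=C(NNc1ccccc1F)c1cccc(NS(=O)(=O)c2cnc(O)nc2O)c1`, which carries 2-fluorophenyl, gives > 20000 nM as a limit too. Compound 3 `Cc1cccc(NNC(=O)c2ccccc2NS(=O)(=O)c2cnc(O)nc2O)c1` gives > 20000 nM as a limit as well, so it has no exact value (the limit of > 20000 nM in this assay, at which 3 of the 3 values shown sit). Compound 4 `O=C(NNc1ccccc1F)c1ccccc1NS(=O)(=O)c1cnc(O)nc1O` differs from compound 3 in one place, with 2-fluorophenyl in place of 3-methylphenyl on an amine nitrogen. For the measured compounds named here, no measured pair shows this change alone, but given compound 2 and its > 20000 nM result, no step beyond the scatter is expected in this assay. The estimated step that the limit leaves unreadable from compound 3 to compound 4 is therefore small. For compound 4 the expected value is 25000 nM within an estimated range of 12000 nM to 50000 nM in this measurement.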

Compound 4, half-maximal inhibitory concentration: > 20000 nM
Compound 4 was reported as a limit; the forecaster's own chance of this, stated with the estimate: 85%; the middle value does not contradict the limit.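

Compound 3 and compound 4 are both reported only as a limit of the assay, so no step between them can be read: the limit of > 20000 nM in this assay, at which 4 of the 4 values shown sit.

The compounds shown leave open whether any change to the shared core gives an exact value in this assay.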